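The source may hold more compounds than are shown below. What is called first, only, known or untested is meant among the compounds shown, and "the series" means these compounds.

Three compounds have been measured:

compound 1 `O=C(NC1=NCCN1)c1ccccc1` gives 0%
compound 2 `O=C(NCC1=NCCN1)c1ccccc1` gives 25%
compound 3 `CC1CN=C(c2ccc(-c3ccccc3)o2)N1` gives 10%

These numbers come from a functional assay for inhibition of Monoamine oxidase (Rattus norvegicus), tested at 0.1 uM; on this read-out higher numbers stand for a stronger effect at the one concentration tested and lower numbers for a weaker effect. On this read-out compound 3 sits second highest of the three. Its nearest neighbour is compound 1, whose value lies lower by a gap within the usual scatter, so the two cannot be told apart. Compound 2 stands higher than compound 3 by a gap beyond the scatter. Among the compounds with values here, no pair of these measured compounds differs in only one place, so no step between measured compounds is available to guide an expectation.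

Compound 4 `OCC1CN=C(c2ccc(-c3ccccc3)o2)N1` is not yet measured. It differs from compound 3 by hydroxy in place of hydrogen on a saturated chain carbon bound to a saturated ring carbon. Within the data shown here, nothing among the measured compounds shows what such an exchange does in this assay, and the starting value of compound 3 is already low, so the expectation is for no step beyond the scatter, with a slight lean downward if anything. The step from compound 3 to compound 4 is expected to be a number 2 percentage points lower from compound 3 to compound 4 (within the scatter). Compound 4 is therefore estimated at 8%, with a plausible range from 0% to 25%.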

Compound 4, a percentage reported as inhibition, at one concentration (the size of the read-out at that concentration, not a potency): 15%
For compound 4 the middle estimate is 7 percentage points below the measured one, within the range that was stated.
By their numbers in this assay, from the lowest: compounds 1, 3, 4 and 2 (each within the scatter of the next, the first and the last beyond it).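

In this assay, within the data shown here, the exchange of hydrogen for hydroxy on a saturated chain carbon bound to a saturated ring carbon gives the first step that can be read, a number 5 percentage points higher from compound 3 to compound 4 (within the scatter), so the two compounds cannot be told apart on this read-out. Among these compounds, no earlier pair differed in only one place, so this is the first indication of what a single exchange does here: going from methyl to hydroxymethyl at this position leaves the read-out within the scatter at the one concentration tested. Nothing available bears on why the result came out this way.

As far as these compounds go, it remains open whether an amine, a carboxylic acid or a longer chain at this same position would give a step beyond the scatter, or would also leave the read-out where compound 3 and compound 4 stand. A single concentration also leaves open whether the two compounds would still be indistinguishable at other concentrations, and whether the same exchange would behave alike on a different core.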